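This account rests on a few compounds, and the source may have more. Where it says the series, first, only, none or still open, it means among the compounds named here.

Compounds measured so far:
compound 1 `CCN(CC)C(=S)SCC1=CCOC1=O` — 1390 nM
compound 2 `O=C1OCC=C1CSC(=S)Nc1ccc(Cl)cc1` — "not active" (no number reported)

Compound 1 carries a diethylamino group on the thiocarbonyl carbon. In a functional assay on HeLa cells (Homo sapiens) for antiproliferative activity, read by MTT assay, with a stated time of 72 h (a lower number here means a stronger inhibitor, a higher number a weaker inhibitor), compound 1 gives 1390 nM, the only numerical result in the set. Compound 2, which carries an anilino-type substituent in place of the dialkylamino group, is recorded in this assay as "not active" (no number reported), without a number. Among the measured compounds shown here, no pair of measured compounds that differ in a single place is available, so no step size has been observed.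

Compound 3 `O=C1OCC=C1CSC(=S)N1CCCC1` is the next entry to be tested. It differs from compound 1 by pyrrolidin-1-yl in place of diethylamino on a thiocarbonyl carbon. Both substituents contain the same count of heavy atoms; the only difference is that the two ethyl chains are joined into a five-membered ring. For compound 3 the value in this assay is expected to lie close to that of compound 1, with the estimated step of a 1.1-fold lower number from compound 1 to compound 3 (0.03 log units; within the scatter) staying within the usual scatter in either direction. Compound 3 is therefore estimated at 1300 nM, with a range from 600 nM to 2800 nM.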

Compound 3, half-maximal inhibitory concentration: 2630 nM
For compound 3 the middle estimate is 2.0-fold (0.31 log units) below the measured one, within the range that was stated.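

In this assay, among the compounds shown here, joining the two ethyl chains of the diethylamino group into pyrrolidin-1-yl on the thiocarbonyl carbon gives a 1.9-fold higher number from compound 1 to compound 3 (0.28 log units; within the scatter), the first single-place step. The place therefore carries either the open diethylamino group or the pyrrolidin-1-yl ring with readings that stay within the scatter of each other, while compound 2 remains the only entry here without a number. No supporting measurement accompanies this step, and nothing can be said about its cause.

Open, as far as these compounds go, is whether the value holds for a larger ring such as piperidin-1-yl or morpholin-4-yl, or for longer chains such as dipropylamino. Also open, from the compounds shown here alone, is whether an unsubstituted anilino group would give a number, which would separate the aromatic ring of compound 2 from its chlorine.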